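The source may report more compounds than this note shows. Statements on the series, on what has been measured and on what is new or still open speak of the compounds shown alone.

Going by the values given here, in a functional assay on HCT-116 cells (Homo sapiens) for cytotoxicity, read by MTT assay, with a stated time of 72 h (on this read-out higher numbers stand for weaker inhibition and lower numbers for stronger inhibition), two compounds on a shared core have numbers so far. Compound 1 `O=C1c2c[n+]([O-])c3ccccc3c2C(=O)c2c1c1ccccc1n2Cc1cn(C[C@H](O)CO)nn1` gives 400 nM and compound 2 `O=C1c2c[n+]([O-])c3ccccc3c2C(=O)c2c1c1ccccc1n2CCCCN1CCCCC1` gives 200 nM on the same read-out. These two numbers lie within the usual scatter of each other, so compound 2 stands level with compound 1 and cannot be ranked against it.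

Compound 3 `CCCN1CCN(CCCCn2c3c(c4ccccc42)C(=O)c2c[n+]([O-])c4ccccc4c2C3=O)CC1` keeps the core and differs from compound 2 in one place. The difference 4-propylpiperazin-1-yl in place of piperidin-1-yl on a saturated chain carbon, four bonds along the chain from an aromatic nitrogen sits on a saturated chain carbon, four bonds along the chain from an aromatic nitrogen.

Among the compounds with values here, only one measured step bears on this change. The step of a 2.0-fold lower number from compound 1 to compound 2 (0.30 log units; within the scatter) exchanged one side group for a quite unlike one and still stayed within the scatter. Within the data shown here, no measured compound carries 4-propylpiperazin-1-yl, so this evidence is indirect. The expected step is no change at the digits printed from compound 2 to compound 3 (within the scatter) and no change beyond the scatter is expected in this assay for this exchange. The estimate for compound 3 is 200 nM with a range from 70 nM to 600 nM as the expected span of a measurement.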

Compound 3, half-maximal inhibitory concentration: 790 nM
Compound 3: the middle estimate sits 4.0-fold (0.60 log units) below what was measured, and the stated range ends below it.
By their numbers in this assay, from the lowest: compounds 2, 1 and 3 (each within the scatter of the next, the first and the last beyond it).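

In this assay, the exchange of piperidin-1-yl for 4-propylpiperazin-1-yl gives a 4.0-fold higher number from compound 2 to compound 3 (0.60 log units; beyond the scatter), the only step among these compounds that lies beyond the scatter. It shows that the number can respond to a change in the group on a saturated chain carbon, four bonds along the chain from an aromatic nitrogen, even though the quite unlike side groups compared earlier stayed within the scatter of each other, and the other new step, a 2.0-fold higher number from compound 1 to compound 3 (0.30 log units; within the scatter), likewise stays within it. Nothing available gives a measured reason for the step from piperidin-1-yl to 4-propylpiperazin-1-yl.

The compounds shown leave open whether the step goes with the second ring nitrogen or with the propyl group, a question that piperazin-1-yl and 4-methylpiperazin-1-yl at the same place could help to separate. They also leave open whether morpholin-4-yl would stand with piperidin-1-yl or with 4-propylpiperazin-1-yl, and whether the same exchange gives a step of similar size on a shorter or a longer chain.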